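Phenylsulfonyl for benzyl on the ring nitrogen of compound 3

The source may hold more compounds than are shown below. What is called first, only, known or untested is meant among the compounds shown, and "the series" means these compounds.

Measured so far:
- compound 1, `Cc1ccc(-c2c(C)c(-c3ccc4c(c3C)CCCO4)c(C(OC(C)(C)C)C(=O)O)c(C)c2NS(C)(=O)=O)cc1C`: 24000 nM
- compound 2, `Cc1ccc(-c2c(C)c(-c3ccc(Cl)c(F)c3)c(C(OC(C)(C)C)C(=O)O)c(C)c2NS(C)(=O)=O)cc1C`: 22000 nM
- compound 3, `Cc1ccc(-c2c(C)c(-c3ccc(C)c(C)c3)c(C(OC(C)(C)C)C(=O)O)c(C)c2NCc2ccccc2)cc1C`: 4000 nM

Of the compounds shown here, three have been tested in an ADME assay on MT4 cells (Homo sapiens) for cytotoxicity, read by MTT assay, with a stated time of 4 days; a higher number here means that more compound is tolerated, a lower number that less compound is tolerated. Compound 3 shows the lowest number of the three: its gap to compound 2 and its gap to compound 1 are both beyond the scatter, so compound 3 is the one of which the cells tolerate least.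

Compound 4, `Cc1ccc(-c2c(C)c(-c3ccc(C)c(C)c3)c(C(OC(C)(C)C)C(=O)O)c(C)c2NS(=O)(=O)c2ccccc2)cc1C`, is not yet measured. It differs from compound 3 in one place: phenylsulfonyl in place of benzyl on a nitrogen on an aromatic ring.

Among the compounds with values here, the only measured step, a 1.1-fold lower number from compound 1 to compound 2 (0.04 log units; within the scatter), changes a different part of the molecule and leaves the nitrogen untouched, so it says nothing direct about this change. Within the data shown here, what the data do show is that compounds 1 and 2, which both carry a sulfonyl group on nitrogen, give the two higher numbers, while compound 3 with its benzyl gives the low one; no single step links them to compound 3.

On that basis compound 4 is expected to move back towards the values of compounds 1 and 2, a step of a 3.0-fold higher number from compound 3 to compound 4 (0.48 log units; beyond the scatter), with the estimate for compound 4 being 12000 nM, between 4500 nM and 32000 nM.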

Compound 4, half-maximal cytotoxic concentration: 11000 nM
Compound 4: the middle estimate sits 1.1-fold (0.04 log units) above what was measured; the range from low to high includes it.
By their numbers in this assay, from the lowest: compound 3; then compounds 4, 2 and 1 (each within the scatter of the next, the first and the last beyond it).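

Within the data shown here, with the rest of the molecule unchanged, this assay gives a first direct reading of the group on this nitrogen on an aromatic ring: phenylsulfonyl in place of benzyl gives a 2.8-fold higher number from compound 3 to compound 4 (0.44 log units; beyond the scatter), a modest step that still lies beyond the scatter. Among these compounds, the earlier step changed a different part of the molecule, so this pair is the first to show that the group on this nitrogen can alter how much compound the cells tolerate, and that the direction here favours phenylsulfonyl over benzyl. Both groups carry the same six-membered aromatic ring of carbon, which points to the link between that ring and the nitrogen as the part that differs, but nothing measured here explains the step.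

The compounds shown leave open whether other links behave in the same way, for example a benzoyl group, which joins the same ring through a carbonyl, or a longer chain ending in an amine. They also leave open whether this step would keep its size and direction on a different version of the rest of the molecule.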